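This account rests on a few compounds, and the source may have more. Where it says the series, first, only, none or still open, it means among the compounds named here.

Compound 1 `Nc1scc(CN2CCN(c3cccnc3)CC2)c1C(=O)c1ccc(Cl)cc1`: 3.2%
Compound 2 `Nc1scc(CN2CCN(c3cccc(F)c3)CC2)c1C(=O)c1cccc(C(F)(F)F)c1`: -11%

Both compounds were tested in a functional assay on CHO cells with adenosine receptor A1 (Homo sapiens) as the target, read by cAMP accumulation and immunoassay, with a stated time of 6 min, tested at 0.01 uM; a lower number here means a stronger effect, a higher number a weaker effect of the compound at the concentration tested. Of the two numbers, compound 1 has the higher one; compound 2, the nearest, lies a step below it that goes beyond the scatter of the measurement. Both readings are small, so neither compound shows more than a weak effect at the concentration tested.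

Compound 3 `Nc1scc(CN2CCN(c3c(F)cc(F)cc3F)CC2)c1C(=O)c1ccc(Cl)cc1` has not yet been measured in this assay. It shares the core of compound 1 and differs from it in one place: 2,4,6-trifluorophenyl in place of pyridin-3-yl on an amine nitrogen in a ring. Within the data shown here, no measured pair shows this same change, so its effect can only be judged from the two readings that exist. Because compound 1 gives 3.2% and compound 2 gives -11%, both close to zero, the change is expected to move the number little: the step of a number 3.2 percentage points lower from compound 1 to compound 3 (within the scatter) is estimated to stay within the usual scatter rather than go clearly up or down. On that basis compound 3 is expected to give about 0%, with a range from -15% to 15%.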

Compound 3, a percentage reported as activity, at one concentration (the size of the read-out at that concentration, not a potency): 4.2%
For compound 3 the middle estimate is 4.2 percentage points below the measured one; the range from low to high includes it.
By their numbers in this assay, from the lowest: compound 2; then compounds 1 and 3 (each within the scatter of the next).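

In this assay, the swap of pyridin-3-yl for 2,4,6-trifluorophenyl on an amine nitrogen in a ring gives a number 1 percentage points higher from compound 1 to compound 3 (within the scatter), the first comparison shown in which only this one place differs. Among these compounds, the ring that enters has carbon only, three fluorine atoms and no hydrogen-bond acceptor, yet at the single concentration tested this reading does not separate it from the pyridin-3-yl ring, so the ring nitrogen of pyridin-3-yl makes no visible difference here. Nothing measured here accounts for this outcome.

Going by these compounds, both groups at this place are six-membered aromatic rings, so it remains open how a non-aromatic group such as cyclohexyl, a small chain such as methyl, or a group carrying a carboxylic acid would read on the same nitrogen. The read-out also comes from one concentration and is not a potency, so these numbers leave open whether the two rings would still read alike at other concentrations.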